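This account rests on a few compounds, and the source may have more. Where it says the series, first, only, none or still open, it means among the compounds named here.

Working notes on the alkyne series.

Compound 1, `CCN(CC)CCNC(=O)C1CC(C(CC)(CC)c2ccc(C#CC(C)(C)O)c(C)c2)=CN1CC`, gives 56.3% in an assay on isolated protein for binding affinity to vitamin D3 receptor (Homo sapiens), read by fluorescence polarization, tested at 1 uM; on this read-out higher numbers stand for more inhibition at the one concentration tested (going by the name of the read-out) and lower numbers for less inhibition. Compound 2, `CCN(CC)CCNC(=O)C1CC(C(CC)(CC)c2ccc(C#CC(O)C3CCC3)c(C)c2)=CN1CC`, gives 49.3% in this assay. For the measured compounds named here, the one step measured so far, a number 7 percentage points lower from compound 1 to compound 2 (within the scatter), replaces the open-chain group on the triple-bonded carbon with one carrying a four-membered ring, and the two numbers cannot be told apart on this read-out. Compound 2 therefore stands level with compound 1; nothing in the data separates them.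

Compound 3, `CCN(CC)CCNC(=O)C1CC(C(CC)(CC)c2ccc(C#CC(O)C3CCCCC3)c(C)c2)=CN1CC`, is not yet measured. The change from compound 2 is cyclohexyl in place of cyclobutyl on a saturated chain carbon bound to an oxygen on a saturated carbon and a triple-bonded carbon. Going by the values given here, the only step that bears on it is a number 7 percentage points lower from compound 1 to compound 2 (within the scatter), which touched the same saturated chain carbon bound to an oxygen and a triple-bonded carbon and stayed inside the scatter. Enlarging the ring there is expected to behave alike, so a step of a number 1.3 percentage points lower from compound 2 to compound 3 (within the scatter) is estimated, with no shift beyond the scatter. For compound 3 the expected value in this assay is 48%, with a range from 33% to 63%.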

Compound 3, a percentage reported as inhibition, at one concentration (the size of the read-out at that concentration, not a potency): 44.2%
Beside the measured number, compound 3's estimate is 3.8 percentage points above it; low and high end bracket the measured number.
By their numbers in this assay, from the lowest: compounds 3, 2 and 1 (each within the scatter of the next, the first and the last beyond it).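

In this assay, the change of ring on the saturated chain carbon bound to an oxygen reads as a number 5.1 percentage points lower from compound 2 to compound 3 (within the scatter) and so leaves cyclobutyl and cyclohexyl indistinguishable at this place. Against the open-chain group the picture differs: cyclohexyl(hydroxy)methyl in place of 1-hydroxy-1-methylethyl gives a number 12.1 percentage points lower from compound 1 to compound 3 (beyond the scatter) and is the first step in the series to pass the scatter, although compound 2 lies within the scatter of both compound 1 and compound 3, so these three support no trend with ring size. No measurement on hand offers an account of either step.

The step from compound 1 to compound 3 swaps the whole group on the triple-bonded carbon, so the compounds shown cannot say whether the ring alone carries it. Also open, from the compounds shown here alone, is what a phenyl ring, a piperidine with its amine, a carboxylic acid or a longer open chain would give on the same saturated chain carbon, and whether the small gaps seen at a single test concentration would hold in a full potency measurement.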